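A few compounds are considered here, and "the series" means these few. Any claim that something is new, unique, unknown or untested is made for them only; others in the source may bear on it.

Compound 1 `CC(=O)c1cc(C)c(OCCCCC#N)cc1O` gives 79% in an assay on isolated protein for inhibition of leukotriene B4 receptor 1 (Homo sapiens), tested at 10 uM; a lower number here means less inhibition, a higher number more inhibition at the concentration tested (going by the name of the read-out). Compound 2 `CCc1cc(C(C)=O)c(O)cc1OCCCCC#N` gives 92% in this assay, and the step of a number 13 percentage points higher from compound 1 to compound 2 (beyond the scatter) follows from the change (methyl in place of hydrogen on a saturated chain carbon bound to an aromatic carbon). Compound 3 `C=CCc1cc(C(C)=O)c(O)cc1OCCCCC` gives 60% in this assay; how its core differs from that of compound 1 is not broken down here. Compound 4 `C=CCc1cc(C(C)=O)c(O)cc1OCCCCCC` carries the change methyl in place of hydrogen on a saturated chain carbon, five bonds along the chain from an oxygen on an aromatic ring relative to compound 3; this is the same kind of change as that from compound 1 to compound 2, but the place differs, since there the methyl enters on a saturated chain carbon bound to an aromatic carbon, whereas here it enters on a saturated chain carbon five bonds along the chain from an oxygen on an aromatic ring. Because the earlier step of a number 13 percentage points higher from compound 1 to compound 2 (beyond the scatter) was modest, and because the place is different, compound 4 is expected to give a step of a number 6 percentage points higher from compound 3 to compound 4 (within the scatter) in this assay. Compound 4 is thus estimated at 66% in this assay, between 46% and 84%.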

Compound 4, a percentage reported as inhibition, at one concentration (the size of the read-out at that concentration, not a potency): 50%
Estimate against measurement, compound 4: 16 percentage points above, and the stated range covers the measured number.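

In this assay, methyl in place of hydrogen on a saturated chain carbon, five bonds along the chain from an oxygen on an aromatic ring, gives a number 10 percentage points lower from compound 3 to compound 4 (within the scatter). Set beside the earlier step, the same kind of change does not carry over with one size or direction from one core to another in this series: the same change on two cores in this assay, a number 13 percentage points higher (beyond the scatter) from compound 1 to compound 2 and a number 10 percentage points lower (within the scatter) from compound 3 to compound 4, 23 percentage points apart, beyond the scatter of two such steps. The two pairs differ in the place of the methyl as well as in the core, and they do not tell these two differences apart.

The compounds shown leave open what this methyl change would give on a core carrying an amine or a carboxylic acid in place of the nitrile. They also leave open what a longer chain would give.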